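Swapping the tail group on a fused bicyclic HeLa inhibitor

The source may hold more compounds than are shown below. What is called first, only, known or untested is meant among the compounds shown, and "the series" means these compounds.

Measured compounds:
compound 1 `C=C(Br)C(=O)Nc1cccc(-c2cn3nc(Cc4cccc(OC)c4)sc3n2)c1`, 2500 nM
compound 2 `COc1cccc(Cc2nn3cc(-c4cccc(N)c4)nc3s2)c1`, 24000 nM

Compound 1 `C=C(Br)C(=O)Nc1cccc(-c2cn3nc(Cc4cccc(OC)c4)sc3n2)c1` is tested in a functional assay on HeLa cells (Homo sapiens) for inhibition, read by cell counting, with a stated time of 4 days (a higher number here means a weaker inhibitor, a lower number a stronger inhibitor), where compound 1 gives 2500 nM. Compound 2 `COc1cccc(Cc2nn3cc(-c4cccc(N)c4)nc3s2)c1` carries a hydrogen in place of the (1-bromoethenyl)carbonyl on the ring nitrogen, and in this assay compound 2 gives 24000 nM. That single step, a 9.6-fold higher number from compound 1 to compound 2 (0.98 log units; beyond the scatter), leaves compound 1 with the lowest of the two numbers.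

Compound 3 `C=C(Br)C(=O)Nc1cccc(-c2cn3nc(-c4cccs4)sc3n2)c1` keeps the amide and changes the other end of the shared core: thiophen-2-yl in place of 3-methoxybenzyl on an aromatic carbon. For the measured compounds named here, no measured step touches that position; the only known step concerns the amide and does not bear on this change. With nothing to tilt the expectation, compound 3 is expected to stay close to compound 1, a step of no change at the digits printed from compound 1 to compound 3 (within the scatter), within the scatter. The estimate for compound 3 in this assay is therefore 2500 nM, ranging from 700 nM to 9000 nM.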

Compound 3, half-maximal inhibitory concentration: 670 nM
Beside the measured number, compound 3's estimate is 3.7-fold (0.57 log units) above it, outside the stated range (below it).
By their numbers in this assay, from the lowest: compound 3; then compound 1; then compound 2.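

Thiophen-2-yl in place of 3-methoxybenzyl on this aromatic carbon gives a 3.7-fold lower number from compound 1 to compound 3 (0.57 log units; beyond the scatter) in this assay, so this end of the shared core also moves the number; the earlier step had changed only the amide end. The 3-methoxybenzyl group, with 9 heavy atoms against 5 for thiophen-2-yl, is therefore not required for inhibition at the level of compound 1 in this series. Nothing available offers an explanation for this step.

Going by these compounds, it remains open whether the lower number belongs to the thiophene ring itself or would also appear with a phenyl or a plain benzyl group at this carbon. Also open, on these data alone, is how an amine or a carboxylic acid would read there, and whether the step would hold without the (1-bromoethenyl)carbonyl group.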